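The compounds below may be only part of what the source reports. "The series", "measured", "known", "first", "only" and "open" are said of these compounds alone.

Of the compounds shown here, three built on the same core have been measured in a functional assay on OVCAR-4 cells (Homo sapiens) for inhibition, read by sulforhodamine B assay, with a stated time of 48 h; a higher number here means a weaker inhibitor of growth, a lower number a stronger inhibitor of growth. Compound 1 `COc1ccc(Sc2nc3cc(N)cc(N)c3nc2-c2ccccc2)cc1` carries a (4-methoxyphenyl)sulfanyl group, and for compound 1 this assay returns only a limit, < 100000 nM. Compound 2 `Nc1cc(N)c2nc(-c3ccccc3)c(Sc3ccc(Cl)c(Cl)c3)nc2c1` carries a (3,4-dichlorophenyl)sulfanyl group, and for compound 2 this assay again stops at a limit, < 100000 nM. For the measured compounds named here, compound 3 `Nc1cc(N)c2nc(-c3ccccc3)c(Oc3ccc(F)cc3)nc2c1` carries a 4-fluorophenoxy group, and in this assay compound 3 gives 35500 nM, the only full number among the three. The steps a step that the two limits leave unreadable from compound 1 to compound 2, a step that the limit leaves unreadable from compound 1 to compound 3 and a step that the limit leaves unreadable from compound 2 to compound 3 cannot be sized because the limit of < 100000 nM in this assay, at which 2 of the 3 values shown sit, hides where the true values actually lie. Compound 4 `Nc1cc(N)c2nc(-c3ccccc3)c(Sc3ccc(F)cc3)nc2c1` differs from compound 3 by (4-fluorophenyl)sulfanyl in place of 4-fluorophenoxy on an aromatic carbon. Going by the values given here, both sulfur-linked compounds measured so far gave only limits, so no readable step shows how much swapping the oxygen link for a sulfur link matters; the step from compound 3 to compound 4 is therefore expected to be a 1.0-fold lower number from compound 3 to compound 4 (0.01 log units; within the scatter), nothing beyond the scatter. Compound 4 is expected to reach total growth inhibition at about 35000 nM, within 10000 nM to 100000 nM.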

Compound 4, concentration for total growth inhibition: 56200 nM
The estimate for compound 4 lay 1.6-fold (0.21 log units) below the measured number; the measured number falls inside the stated range.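

For the compounds shown here, with compound 4, a sulfur-linked member of the series gives a full number for the first time, so the exchange of the oxygen link for a sulfur link can finally be sized: in this assay it is a 1.6-fold higher number from compound 3 to compound 4 (0.20 log units; within the scatter). With the 4-fluorophenyl part kept the same, this change on the aromatic carbon next to the ring nitrogen therefore shows no effect that stands out from ordinary repeat variation. The steps to compound 4 from compound 1 and from compound 2 still cannot be read, and the reason is a limit: the limit of < 100000 nM in this assay, at which 2 of the 4 values shown sit.

On these data alone, how the 3,4-dichlorophenyl and 4-methoxyphenyl groups on a sulfur truly compare with 4-fluorophenyl remains open. The compounds shown also leave open whether an amine link at this position, in place of oxygen or sulfur, would behave the same way.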